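A Fluorophenyl Extension on a Weakly Cytotoxic Core

A few compounds are considered here, and "the series" means these few. Any claim that something is new, unique, unknown or untested is made for them only; others in the source may bear on it.

Going by the values given here, compound 1 `C=CC[C@H]1C[C@@H]([C@@H](O)c2ccccc2)CO[C@@H]1c1ccccc1` is tested in a functional assay on HL-60 cells (Homo sapiens) for cytotoxicity, read by WST assay, with a stated time of 48 h (a higher number here means a weaker inhibitor, a lower number a stronger inhibitor), where compound 1 gives 36000 nM, the highest of the two numbers measured so far. Compound 2 `COc1ccc(/C=C/C[C@H]2C[C@@H]([C@@H](O)c3ccc(OC)c(OC)c3)CO[C@@H]2c2ccc(OC)c(OC)c2)cc1OC` gives 34700 nM in this assay, a value within the usual scatter of that of compound 1. Compound 3 `O[C@@H](c1ccccc1)[C@H]1CO[C@H](c2ccccc2)[C@@H](C/C=C/c2ccc(F)cc2)C1` carries the change 2-(4-fluorophenyl)ethenyl in place of vinyl on a saturated chain carbon bound to a saturated ring carbon relative to compound 1. Compound 2, which differs from compound 1 in several places at once, shows no shift beyond the scatter, so the step of a 1.4-fold lower number from compound 1 to compound 3 (0.16 log units; within the scatter) is expected to be small, leaning toward a stronger inhibitor. Compound 3 is expected to reach 25000 nM, between 8000 nM and 70000 nM.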

Compound 3, half-maximal inhibitory concentration: 8110 nM
Compound 3: the middle estimate sits 3.1-fold (0.49 log units) above what was measured; measured number inside the range.
By their numbers in this assay, from the lowest: compound 3; then compounds 2 and 1 (each within the scatter of the next).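

In this assay the swap of vinyl for 2-(4-fluorophenyl)ethenyl on this saturated chain carbon gives a step beyond the scatter (a 4.4-fold lower number from compound 1 to compound 3 (0.65 log units; beyond the scatter)), so a change at this one place can move the number, which compound 2, altered in several places at once, could not show. The entering group brings an aromatic ring and a fluorine together, so the step belongs to the whole group and not to either part. Nothing measured here accounts for the step.

From the compounds shown here alone, whether a plain 2-phenylethenyl would do the same remains open. So does the effect of an amine or a carboxylic acid on that ring in place of fluorine.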